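A few compounds are considered here, and "the series" means these few. Any claim that something is new, unique, unknown or untested is made for them only; others in the source may bear on it.

In an ADME assay on microsomes from liver (Rattus norvegicus) for metabolic stability, using NADPH, with a stated time of 10 min (on this read-out lower numbers stand for a less stable compound and higher numbers for a more stable compound), compound 3 (`NC(=O)NCCCCN(C[C@H]1Cc2ncccc2CN1)[C@H]1CCCc2cccnc21`) gives 1%, within the scatter of compound 1 (`CN(C[C@H]1Cc2ncccc2CN1)[C@H]1CCCc2cccnc21`) at 7% and of compound 2 (`NC/C=C/CN(C[C@H]1Cc2ncccc2CN1)[C@H]1CCCc2cccnc21`) at 11%. Compound 4 (`CN(CCCCN(C[C@H]1Cc2ncccc2CN1)[C@H]1CCCc2cccnc21)C1CCC(F)(F)CC1`) differs from compound 3 by a group of 10 heavy atoms (7 carbon, 1 nitrogen, 2 fluorine; one six-membered non-aromatic ring of carbon only) in place of a group of 4 heavy atoms (1 carbon, 2 nitrogen, 1 oxygen; no ring), on a saturated chain carbon, four bonds along the chain from an amine nitrogen. Among the compounds with values here, three measured steps bear on this change at the chain: a number 6 percentage points lower from compound 1 to compound 3 (within the scatter), a number 10 percentage points lower from compound 2 to compound 3 (within the scatter) and a number 4 percentage points higher from compound 1 to compound 2 (within the scatter). All three stay within the scatter. Within the data shown here, no measured compound carries a six-membered non-aromatic ring of carbon only or any fluorine on the chain, so the entering group itself remains untested. No shift beyond the scatter is expected in this assay. The expected step is a number 4 percentage points higher from compound 3 to compound 4 (within the scatter). The estimate for compound 4 is 5%, with an expected range of 0% to 15%.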

Compound 4, percent of the compound remaining: 8%
Compound 4: middle estimate off by 3 percentage points, on the low side; low and high end bracket the measured number.
By their numbers in this assay, from the lowest: compounds 3, 1, 4 and 2 (each within the scatter of the next).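

In this assay, the group with the six-membered non-aromatic ring of carbon only and fluorine, placed on the saturated chain carbon in place of ureido, gives a number 7 percentage points higher from compound 3 to compound 4 (within the scatter). This position therefore takes a much larger, ring-bearing group without a shift beyond the scatter, and neither the ring nor the fluorine separates compound 4 from compound 3 on this read-out. No measurement at hand explains this result.

From the compounds shown here alone, it remains open whether a carboxylic acid, a morpholine or a shorter chain here would move the number beyond the scatter. The same carbon ring without fluorine also remains to be compared.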